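Pyrrolidinyl for dimethylamino on the small core

The source may hold more compounds than are shown below. What is called first, only, known or untested is meant among the compounds shown, and "the series" means these compounds.

Compound 3 `CN(C)c1c(C#N)c2c(N)ncnc2n1C` is the smallest member of the set. In an assay on isolated protein for inhibition of Leucine-rich repeat serine/threonine-protein kinase 2 variant G2019S (Homo sapiens), read by TR-FRET and LanthaScreen, with stated times of 50 min and 30 min, in the presence of a further agent that is not named here (on this read-out higher numbers stand for weaker inhibition and lower numbers for stronger inhibition), compound 3 gives 3760 nM, the highest number of the three measured. Compound 2 `C[C@@H]1CCCN1c1c(C#N)c2c(N)nc(Nc3ccn(C)n3)cc2n1C` gives 206 nM in this assay, and compound 1 `Cc1nn(CC2(O)COC2)cc1Nc1nc(N)c2c(C#N)c(N3CCC[C@H]3C)n(C)c2n1` gives 51 nM; both numbers lie beyond the scatter from that of compound 3, but each of these compounds differs from compound 3 in more than one place, so no single step can be read from them. Compound 4 `Cn1c(N2CCCC2)c(C#N)c2c(N)ncnc21` has not been measured. It differs from compound 3 in one place only: pyrrolidin-1-yl in place of dimethylamino on an aromatic carbon. Compounds 1 and 2 both carry a five-membered non-aromatic ring with one hetero atom in this same place, yet they also carry a further group that compound 3 and compound 4 lack, so their numbers cannot be credited to the ring alone. The expectation for compound 4 is a moderate step toward a lower number in this assay, a 2.4-fold lower number from compound 3 to compound 4 (0.37 log units; beyond the scatter), of a size near the edge of the scatter. Compound 4 is estimated at 1600 nM in this assay, with a range from 500 nM to 5000 nM.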

Compound 4, half-maximal inhibitory concentration: 1910 nM
Beside the measured number, compound 4's estimate is 1.2-fold (0.08 log units) below it; the measured number falls inside the stated range.
By their numbers in this assay, from the lowest: compound 1; then compound 2; then compounds 4 and 3 (each within the scatter of the next).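

In this assay, going by these compounds alone, pyrrolidin-1-yl in place of dimethylamino on the aromatic carbon gives a 2.0-fold lower number from compound 3 to compound 4 (0.29 log units; within the scatter), the first step in the set that can be read at this place, and it shows that the two groups are not told apart on the small core, although the entering group brings a five-membered non-aromatic ring where the leaving group has none. Closing the ring therefore does not by itself separate compound 4 from compound 3, while steps from either of these to compound 1 or compound 2 cannot be read, as those compounds differ from them in more than one place. Nothing on hand offers an explanation for this result.

Still open, from the compounds shown here alone, is how a methyl-substituted pyrrolidin-1-yl would read on the small core, and whether piperidin-1-yl, morpholin-4-yl or azetidin-1-yl at this place would stay within the scatter of compound 4 or move away from it. Also open, going by these compounds, is how much of the numbers for compound 1 and compound 2 belongs to the further groups they carry on the core, and whether the change from dimethylamino to pyrrolidin-1-yl would read the same alongside those groups.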